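The compounds below may be only part of what the source reports. "The series", "measured", "known", "first", "only" and "open" are said of these compounds alone.

Measured compounds in a functional assay on A549 cells (Homo sapiens) for antiproliferative activity, read by MTT assay, with a stated time of 48 h; a lower number here means a stronger inhibitor, a higher number a weaker inhibitor:
- compound 1 `O=C(/C=C\Nc1ccc(F)cc1)c1cn(-c2ccccc2)nc1-c1ccc(F)cc1` gives 5780 nM
- compound 2 `O=C(/C=C\Nc1ccc(O)cc1)c1cn(-c2ccccc2)nc1-c1ccc(F)cc1` gives 1500 nM
- compound 3 `COc1ccc(N/C=C\C(=O)c2cn(-c3ccccc3)nc2-c2ccc(F)cc2)cc1` gives 8900 nM

Compound 3 carries the highest number of the three. Its nearest neighbour is compound 1, the step of a 1.5-fold higher number from compound 1 to compound 3 (0.19 log units; within the scatter) lying within the scatter; its furthest is compound 2, the step of a 5.9-fold higher number from compound 2 to compound 3 (0.77 log units; beyond the scatter) lying beyond it. For the measured compounds named here, the one step that clearly moves the number is a 3.9-fold lower number from compound 1 to compound 2 (0.59 log units; beyond the scatter), and all three steps sit on the aniline ring at the far end of the enaminone.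

Compound 4 `COc1ccc(N/C=C\C(=O)c2cn(-c3ccccc3)nc2-c2cc(OC)c(OC)c(OC)c2)cc1` changes a different part of the molecule: 3,4,5-trimethoxyphenyl in place of 4-fluorophenyl on an aromatic carbon. Going by the values given here, none of the measured steps touches this aromatic carbon on the five-membered ring, so nothing measured bears directly on the change; the aniline-ring steps say only that the series responds modestly to substitution elsewhere. Among the compounds with values here, with no step to lean on, no direction beyond the scatter is expected for a 2.2-fold lower number from compound 3 to compound 4 (0.35 log units; beyond the scatter), and the range has to be left wide.

Compound 4 is therefore estimated at 4000 nM, with a range from 600 nM to 20000 nM.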

Compound 4, half-maximal inhibitory concentration: 4780 nM
Beside the measured number, compound 4's estimate is 1.2-fold (0.08 log units) below it, and the stated range covers the measured number.
By their numbers in this assay, from the lowest: compound 2; then compounds 4, 1 and 3 (each within the scatter of the next).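

In this assay, for the compounds shown here, the first change at this carbon of the five-membered ring, 3,4,5-trimethoxyphenyl in place of 4-fluorophenyl, gives a 1.9-fold lower number from compound 3 to compound 4 (0.27 log units; within the scatter). The entering group brings 12 heavy atoms against 7 and 3 hydrogen-bond acceptors against 0, and the number still does not move beyond the scatter, so this position tolerates a clearly larger aryl group in this assay without a measurable gain or loss. This reading rests on a single pair with the methoxy group kept on the aniline ring, and no measurement at hand offers a cause for the size of the step.

Still open, as far as these compounds go, is whether the same exchange stays within the scatter when the aniline ring carries the hydroxy group of compound 2, the one substituent there with a step beyond the scatter against both fluoro and methoxy. Also open, from the compounds shown here alone, is how this carbon responds to a phenyl ring bearing a single methoxy group, an amine or a carboxylic acid, or to a morpholine or a longer alkyl chain in place of the aryl group.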